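Chloro to Bromo on the Fused Ring of Compound 1

A few compounds are considered here, and "the series" means these few. Any claim that something is new, unique, unknown or untested is made for them only; others in the source may bear on it.

Compound 1 `COc1ccc2c(C3CCc4ccc(Cl)cc43)ncnc2c1OC` gives the lowest of the two numbers in an assay on isolated protein for inhibition of dual specificity calcium/calmodulin-dependent 3',5'-cyclic nucleotide phosphodiesterase 1B (Homo sapiens) (on this read-out higher numbers stand for weaker inhibition and lower numbers for stronger inhibition), at 4 nM. Compound 2 `COc1ccc2c(N3C[C@H](C)C[C@H](C)C3)ncnc2c1OC` gives 70 nM in this assay, a gap from compound 1 that lies beyond the scatter. Compound 3 `COc1ccc2c(C3CCc4ccc(Br)cc43)ncnc2c1OC` differs from compound 1 by bromo in place of chloro on an aromatic carbon, a bromo in place of chloro on an aromatic carbon. For the measured compounds named here, no measured pair shows this exchange, so its size is unknown; a step within the scatter, in either direction, is expected. Compound 3 is therefore estimated at 4 nM, within a range from 1.5 nM to 12 nM. This estimate means an expected step of no change at the digits printed from compound 1 to compound 3 (within the scatter).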

Compound 3, half-maximal inhibitory concentration: 8 nM
Beside the measured number, compound 3's estimate is 2.0-fold (0.30 log units) below it, within the range that was stated.
By their numbers in this assay, from the lowest: compounds 1 and 3 (each within the scatter of the next); then compound 2.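

Exchanging chloro for bromo on this aromatic carbon gives, in this assay, a 2.0-fold higher number from compound 1 to compound 3 (0.30 log units; within the scatter). The position therefore takes either of these two halogens with no change that can be told from the scatter, something the earlier pair could not show, as its two members differ in more than one place. Nothing available here offers an explanation for this result.

The compounds shown leave open whether fluoro would fit the same picture, and whether an amine or a nitrile on this carbon would hold the number.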